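The compounds below may be only part of what the source reports. "The series", "measured", "known", "first", "only" and "open" are said of these compounds alone.

Measured so far:
- compound 1 `O=C(COc1ccc(C(=O)/C=C/c2ccc(Cl)cc2Cl)cc1)N[C@H]1CCOC1=O`: 8040 nM
- compound 2 `O=C1OCC[C@@H]1NC(=S)SCCOc1ccccc1Cc1ccccc1`: > 64000 nM

Among the measured compounds shown here, in a functional assay on PC-3 cells (Homo sapiens) for antiproliferative activity, read by MTT assay, with a stated time of 72 h (on this read-out higher numbers stand for weaker inhibition and lower numbers for stronger inhibition), compound 1 gives 8040 nM, the only numeric value in the set. Compound 2 gives no number in this assay but only a limit, > 64000 nM. That is the limit of > 64000 nM in this assay, at which 1 of the 2 values shown sits, so compound 1 stands as the sole anchor against which anything new can be placed.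

The next compound, compound 3 `O=C(COc1ccc(C(=O)/C=C/c2ccccc2)cc1)N[C@H]1CCOC1=O`, keeps the core of compound 1 and changes only the aryl group at the far end of the enone: phenyl in place of 2,4-dichlorophenyl on a double-bonded chain carbon bound to a double-bonded chain carbon. For the measured compounds named here, no pair of measured compounds differing in one place exists here, so the size of this step can only be judged from the anchor itself and the change as counted.

Without a measured precedent, the expectation for the step from compound 1 to compound 3 in this assay is a shift toward weaker inhibition, by an amount somewhat beyond the usual scatter, a 2.5-fold higher number from compound 1 to compound 3 (0.40 log units; beyond the scatter). Compound 3 is therefore estimated at 20000 nM in this assay, with a plausible range from 6000 nM to 64000 nM.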

Compound 3, half-maximal inhibitory concentration: 56800 nM
Compound 3: middle estimate off by 2.8-fold (0.45 log units), on the low side, within the range that was stated.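

In this assay, the position on a double-bonded chain carbon bound to a double-bonded chain carbon now has its first measured step: phenyl in place of 2,4-dichlorophenyl gives a 7.1-fold higher number from compound 1 to compound 3 (0.85 log units; beyond the scatter), so activity in this pair is not indifferent to the aryl group at this end of the enone. The change removes only the two chlorine atoms, while the six-membered aromatic ring of carbon, the hydrogen-bond counts and the absence of net charge stay as they were, which ties the step in this single pair to those two chlorine atoms. Compound 2 remains a limit and not a number, and it differs from compound 1 in more than one place, so it adds no step to this reading: the limit of > 64000 nM in this assay, at which 1 of the 3 values shown sits.

Only one replacement at this position is shown, so it stays open whether a single chlorine on the phenyl ring, or a methoxy or trifluoromethyl group there, would sit nearer compound 1 or nearer compound 3. Whether a step of this size would recur on another core or in another cell line cannot be read from one pair.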